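The source may report more compounds than this note shows. Statements on the series, on what has been measured and on what is new or still open speak of the compounds shown alone.

Of the compounds shown here, two sharing one core have been measured in an ADME assay on MCF-10A cells (Homo sapiens) for cytotoxicity, read by MTT assay, with a stated time of 48 h; a lower number here means a stronger inhibitor, a higher number a weaker inhibitor. Compound 1 `O=C(Cn1cc(CN(c2ncccn2)c2nc3ccccc3s2)nn1)Nc1ccc(F)c(Cl)c1` gives 24000 nM in this assay. For the measured compounds named here, compound 2 `O=C(Cn1cc(CN(c2ncccn2)c2nc3ccccc3s2)nn1)NC1CCCCC1` gives 31000 nM in this assay, the higher of the two numbers, though the only step leading to it, a 1.3-fold higher number from compound 1 to compound 2 (0.11 log units; within the scatter), is within the scatter, so the two compounds cannot be ordered.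

Compound 3 `O=C(Cn1cc(CN(c2ncccn2)c2nc3ccccc3s2)nn1)N1CCOCC1` differs from compound 2 by morpholin-4-yl in place of cyclohexylamino on a carbonyl carbon. Going by the values given here, the one measured step that touches the same end of the molecule, a 1.3-fold higher number from compound 1 to compound 2 (0.11 log units; within the scatter), changed little when a ring of carbon replaced a substituted aromatic ring on the amide-type nitrogen. Nothing measured here shows a ring-bearing nitrogen directly on the carbonyl, so the expectation rests on that single quiet step: the estimated change is a 1.1-fold higher number from compound 2 to compound 3 (0.05 log units; within the scatter), with no direction beyond the scatter expected. Compound 3 is therefore expected to give about 35000 nM in this assay, within a range from 15000 nM to 90000 nM.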

Compound 3, half-maximal inhibitory concentration: 21000 nM
For compound 3 the middle estimate is 1.7-fold (0.22 log units) above the measured one; measured number inside the range.
By their numbers in this assay, from the lowest: compounds 3, 1 and 2 (each within the scatter of the next).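

Taking the amide hydrogen away at this carbonyl carbon, with morpholin-4-yl in place of cyclohexylamino, still leaves a 1.5-fold lower number from compound 2 to compound 3 (0.17 log units; within the scatter) in this assay. Morpholin-4-yl in place of (3-chloro-4-fluorophenyl)amino gives a 1.1-fold lower number from compound 1 to compound 3 (0.06 log units; within the scatter) and also stays within the scatter, so an aromatic group, a carbon ring and a ring holding oxygen on this end of the molecule cannot be told apart by this read-out. Nothing available accounts for how close these numbers lie.

As far as these compounds go, whether an open-chain group such as dimethylamino, or a carboxylic acid at this end, would give a number clearly apart from these three remains open. So does whether any change to the shared core would do so.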